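Methoxy for Trifluoromethyl on the Aryl Triazole Pendant

The source may hold more compounds than are shown below. What is called first, only, known or untested is meant among the compounds shown, and "the series" means these compounds.

For the measured compounds named here, compound 1 `C=C1C(=O)[C@]23C[C@@]1(O)CC[C@H]2c1ccc(O)c(C)c1[C@@H]3Cn1cc(-c2ccc(C(F)(F)F)cc2)nn1` is the one compound in this set with a numerical result: in a functional assay on HL-60 cells (Homo sapiens) for cytotoxicity, read by MTT assay, with a stated time of 4 days (on this read-out higher numbers stand for weaker inhibition and lower numbers for stronger inhibition), compound 1 gives 720 nM. Compound 2 `Cc1c(O)ccc2c1[C@H](Cn1cc(-c3ccc(C(F)(F)F)cc3)nn1)[C@@]13CC(=O)[C@@](C)(CC[C@@H]21)C3`, which carries a different core, is recorded only as a limit and not as a number: in this assay compound 2 gives > 20000 nM. That result is the limit of > 20000 nM in this assay, at which 1 of the 2 values shown sits, and it is used here only as a limit.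

Compound 3 `C=C1C(=O)[C@]23C[C@@]1(O)CC[C@H]2c1ccc(O)c(C)c1[C@@H]3Cn1cc(-c2ccc(OC)cc2)nn1` keeps the core of compound 1 and alters only the pendant ring on the triazole: methoxy in place of trifluoromethyl on an aromatic carbon. No measured pair in the set differs in just this way, so the size of the change from compound 1 to compound 3 cannot be read off from the data shown. The step of a 1.8-fold higher number from compound 1 to compound 3 (0.26 log units; within the scatter) is expected to be small, at or only a little beyond the usual scatter, with weaker inhibition judged somewhat more likely than stronger. Compound 3 is accordingly estimated at 1300 nM in this assay, with a range from 350 nM to 5000 nM.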

Compound 3, half-maximal inhibitory concentration: 1150 nM
Compound 3: the middle estimate sits 1.1-fold (0.05 log units) above what was measured; the range from low to high includes it.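

In this assay, replacing trifluoromethyl with methoxy on an aromatic carbon para to a large group gives a 1.6-fold higher number from compound 1 to compound 3 (0.20 log units; within the scatter), the first measured read on this position in the series. On this read-out, with the core of compound 1, the 4-(trifluoromethyl)phenyl and 4-methoxyphenyl pendants are not told apart, even though the exchange adds a hydrogen-bond acceptor and leaves the pendant with fewer heavy atoms. Nothing recorded here speaks to a cause for this step, since the only other result comes from a compound with a different core.

On these data alone, whether the same exchange would be equally silent on the core of compound 2 remains open, as that compound is recorded only as a limit and has no partner on its own core in the set. Also open, as far as these compounds go, is how far this position accepts other groups, for instance an amine, a carboxylic acid or a longer chain such as butoxy, and whether a substituent of any kind on this aromatic carbon matters at all compared with plain hydrogen there.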